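A Nitro Swap on the Weakest-Known Series

A few compounds are considered here, and "the series" means these few. Any claim that something is new, unique, unknown or untested is made for them only; others in the source may bear on it.

In a functional assay on HL-60 cells (Homo sapiens) for antiproliferative activity, read by MTT assay, with a stated time of 24 h (a higher number here means a weaker inhibitor, a lower number a stronger inhibitor), compound 2 (`Cc1cccc(Nc2ncc(Br)c(Oc3cccc(F)c3)n2)c1`) gives 15500 nM and so holds the lower of the two actual numbers measured. Compound 1 (`CCOc1ccccc1Oc1nc(Nc2cccc(C)c2)ncc1Br`) gives 34700 nM and that gap lies beyond the scatter. Compound 3 (`Cc1cccc(Nc2ncc(Br)c(Oc3cc(Cl)cc(Cl)c3)n2)c1`) reaches only a limit of the assay at > 50000 nM and yields no number.

Compound 4 (`Cc1cccc(Nc2ncc(Br)c(Oc3cccc([N+](=O)[O-])c3)n2)c1`) is still unmeasured. It carries nitro in place of fluoro on an aromatic carbon of compound 2, meta to a large group (nitro in place of fluoro on an aromatic carbon). For the measured compounds named here, only one measured step touches this part of the structure: an at least 3.2-fold higher number from compound 2 to compound 3 (0.50 log units; beyond the scatter) with 3,5-dichlorophenyl in place of 3-fluorophenyl on an oxygen on an aromatic ring. Going by these compounds, that step is bounded by a limit, so its true size stays open, and its entering group differs from nitro. Going by the values given here, it is thin guidance, yet it is the only guidance, and it points upward. Among the compounds with values here, with an at least 3.2-fold higher number from compound 2 to compound 3 (0.50 log units; beyond the scatter) as the sole guide, a small move towards a higher number in this assay is expected, quite possibly one that stays within the scatter. The expected change is a 1.4-fold higher number from compound 2 to compound 4 (0.15 log units; within the scatter) as an estimate only. Compound 4 is estimated at 22000 nM with an expected range from 9000 nM to 50000 nM in this assay for now.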

Compound 4, half-maximal inhibitory concentration: 38700 nM
Estimate against measurement, compound 4: 1.8-fold (0.25 log units) below; the measured number falls inside the stated range.
By their numbers in this assay, from the lowest: compound 2; then compounds 1 and 4 (each within the scatter of the next). At a limit, above all of these: compound 3.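

In this assay, for the compounds shown here, nitro in place of fluoro on an aromatic carbon gives a 2.5-fold higher number from compound 2 to compound 4 (0.40 log units; beyond the scatter), the first step at this part of the structure with a measured number at both ends. Going by these compounds alone, compound 3, the only earlier change here, carries a limit of the assay and not a number: the limit of > 50000 nM in this assay, at which 1 of the 4 values shown sits. Compound 4 now shows that one group exchanged at this place, meta to a large group, is enough to move the number upward beyond the scatter, in the same direction as an at least 3.2-fold higher number from compound 2 to compound 3 (0.50 log units; beyond the scatter), although two steps with different entering groups make no general rule.

The exchange changes the heavy-atom count and the hydrogen-bond acceptor count together, from one fluorine and no acceptors to nitro with its three heavy atoms and two acceptors, so the compounds shown cannot tell which of these differences goes with the higher number. Going by these compounds, an amine or a methoxy group at the same place would be needed to separate them, and whether any group here can bring the number below that of compound 2 remains open.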